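The source may report more compounds than this note shows. Statements on the series, on what has been measured and on what is new or still open speak of the compounds shown alone.

Working notes on the series.

Compound 1 `O=c1[nH]nc2n(c1=O)CCN2c1ccccc1` gives 0% in a functional assay on A549 cells (Homo sapiens) for antiproliferative activity, with a stated time of 72 h, tested at 10 ug/mL; a lower number here means a weaker effect, a higher number a stronger effect of the compound at the concentration tested. Compound 2 `Cc1ccccc1N1CCn2c1n[nH]c(=O)c2=O` gives 24% in this assay. The change from compound 2 to compound 1 is hydrogen in place of methyl on an aromatic carbon, and the step it made is a number 24 percentage points lower from compound 2 to compound 1 (beyond the scatter). Compound 3 `Cc1ccc(N2CCn3c2n[nH]c(=O)c3=N)cc1` gives 37% in this assay, the highest of the three numbers; the difference between its core and the core of compound 2 is not broken down here.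

Compound 4 `N=c1c(=O)[nH]nc2n1CCN2c1ccccc1` has not yet been measured in this assay. Going by the values given here, it differs from compound 3 by hydrogen in place of methyl on an aromatic carbon, the same kind of change as the one from compound 2 to compound 1, though in compound 2 the methyl sits ortho to a large group and in compound 3 it sits para to a large group. Among the compounds with values here, the expected step from compound 3 to compound 4 is a number 22 percentage points lower from compound 3 to compound 4 (beyond the scatter), resting on the one measured instance of this change, a number 24 percentage points lower from compound 2 to compound 1 (beyond the scatter), and on the value of compound 3, 37%. Compound 4 is therefore estimated at 15% in this assay, with a range from 0% to 32%.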

Compound 4, a percentage reported as inhibition, at one concentration (the size of the read-out at that concentration, not a potency): 7%
Compound 4: middle estimate off by 8 percentage points, on the high side; the range from low to high includes it.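

In this assay the new step, a number 30 percentage points lower from compound 3 to compound 4 (beyond the scatter), stands with the earlier one, and the two cannot be told apart: the same change on two cores in this assay, a number 24 percentage points lower (beyond the scatter) from compound 2 to compound 1 and a number 30 percentage points lower (beyond the scatter) from compound 3 to compound 4, 6 percentage points apart, within the scatter of two such steps. Within these two pairs, hydrogen in place of methyl therefore carries from one core to the other with a similar size, even though the methyl in compound 3 sits para to a large group and the methyl in compound 2 sits elsewhere on the ring. Two pairs read at a single concentration do not show that the step would hold on any further core, and they give neither a potency nor a cause for the loss.

Going by these compounds, what a chlorine, a methoxy group or a longer alkyl chain on that aromatic ring would do remains open. Also open, on these data alone, is whether the place of the methyl matters on a single core, as each core appears here with its methyl in one place only.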